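This account rests on a few compounds, and the source may have more. Where it says the series, first, only, none or still open, it means among the compounds named here.

Measured in an assay on membranes from HeLa cells for displacement of a labelled ligand from adenosine receptor A3 (Homo sapiens), read by scintillation counting, with a stated time of 180 min, tested at 1 uM; a higher number here means more inhibition at the concentration tested (going by the name of the read-out), a lower number less inhibition:
compound 1 `COC(=O)C1=C(C)NC(=O)NC1c1cccs1`: 3%
compound 2 `CC1=C(C(=O)OC(C)(C)C)C(c2cccs2)NC(=O)N1`: 7%
compound 3 `CC1=C(C(=O)SC(C)C)C(c2ccoc2)NC(=O)N1`: 3%

Compound 3 stands level with compound 1 at the digits shown, the two of them together the lowest of the three numbers. Its nearest neighbour is compound 1, with no change at the digits shown, within the scatter. For the measured compounds named here, its furthest is compound 2, whose value, 7%, also lies within the scatter of compound 3; no single-change step links these two, so only the two numbers speak.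

Compound 4 `CC1=C(C(=O)SC(C)C)C(c2cccs2)NC(=O)N1` is not yet measured. It differs from compound 3 in one place: thiophen-2-yl in place of furan-3-yl on a saturated ring carbon.

Going by the values given here, the one measured step, a number 4 percentage points higher from compound 1 to compound 2 (within the scatter), swaps the alcohol part of the ester and is within the scatter. Among the compounds with values here, no measured step exchanges the five-membered aromatic ring on the saturated ring carbon, so nothing bears directly on the change to compound 4. Within the data shown here, all three measured compounds sit at the low end of the read-out, and the one step known is flat. The step of a number 1 percentage points higher from compound 3 to compound 4 (within the scatter) is therefore expected to stay within the scatter, with no direction favoured.

Compound 4 is estimated at 4%, in the range 0% to 15%, in this assay.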

Compound 4, a percentage reported as inhibition, at one concentration (the size of the read-out at that concentration, not a potency): 1%
Compound 4: middle estimate off by 3 percentage points, on the high side; measured number inside the range.
By their numbers in this assay, from the lowest: compounds 4, 1, 3 and 2 (each within the scatter of the next).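

In this assay, the exchange on the saturated ring carbon now has a measured step: a number 2 percentage points lower from compound 3 to compound 4 (within the scatter), with thiophen-2-yl in place of furan-3-yl, lies within the scatter, so this pair of five-membered aromatic rings is not told apart at this position. With thiophen-2-yl held constant, the group on the carbonyl carbon can now be read for the thioester as well: a number 2 percentage points lower from compound 1 to compound 4 (within the scatter) for isopropylsulfanyl in place of methoxy and a number 6 percentage points lower from compound 2 to compound 4 (within the scatter) for isopropylsulfanyl in place of tert-butoxy, both within the scatter. Nothing available bears on the reason for these numbers.

All four compounds sit at the low end of the read-out at this single concentration, so these results do not show whether either position can support a clearly higher number. Still open, going by these compounds, is whether a phenyl ring or an aminomethyl-substituted thiophene on the saturated ring carbon, or a longer chain such as octylsulfanyl on the carbonyl carbon, would move the read-out beyond the scatter.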